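The compounds below may be only part of what the source reports. "The series", "measured", "known", "first", "only" and "open" are said of these compounds alone.

Working notes on the series. The shared core is that of compound 1 `COc1ccc(-c2cc(=O)c3c(OC)cc(OC)cc3[nH]2)cc1`. In a functional assay on SEM cells (Homo sapiens) for antiproliferative activity, with a stated time of 72 h (on this read-out higher numbers stand for an effect only at larger amounts of compound and lower numbers for an effect already at smaller amounts), compound 1 reaches only a limit of the assay, > 31100 nM. Compound 2 `COC(=O)c1cc(=O)c2c(OC)cc(OC)cc2n1C` carries a methyl ester and a methyl on the ring nitrogen in place of the aryl group. In this assay compound 2 likewise reaches only a limit, > 19000 nM. Compound 3 `COc1ccc(-c2cc(=O)c3c(OC)cc(OC)cc3n2S(=O)(=O)c2cccc([N+](=O)[O-])c2)cc1` bears a 3-nitrophenyl sulfonyl on the ring nitrogen. In this assay compound 3 has no result at all, its entry reading "not determined" (no result reported), so it stands without a number. The two other values in the set are the limits the limit of > 19000 nM in this assay, at which 1 of the 3 values shown sits, and (the limit of > 31100 nM in this assay, at which 1 of the 3 values shown sits). For the measured compounds named here, no step between measured compounds can be computed: the two limits show only that neither compound 1 nor compound 2 gives an effect within the range tested.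

Compound 4 `COc1ccc(-c2cc(=O)c3c(OC)cc(OC)cc3n2S(=O)(=O)c2c(F)c(F)c(F)c(F)c2F)cc1` differs from compound 3 by 2,3,4,5,6-pentafluorophenyl in place of 3-nitrophenyl on a sulfonyl sulfur. Going by the values given here, with compound 3 unmeasured, no size of step in this assay can be fixed for this change, and no direction beyond the scatter is claimed. The nearest measured relative of compound 4 is compound 1, which stands at a limit > 31100 nM. The expectation for compound 4 in this assay is estimated at 20000 nM, within 4000 nM to 60000 nM, and a limit rather than a number is the likelier outcome.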

Compound 4, half-maximal effective concentration: 3900 nM
Estimate against measurement, compound 4: 5.1-fold (0.71 log units) above; the measured number lies below the stated range.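

For the compounds shown here, compound 3 carries no number in this assay, so no step to compound 4 can be read, and the value of compound 4 stands without a measured partner. The compounds shown leave open whether the 2,3,4,5,6-pentafluorophenyl group or the sulfonyl on the ring nitrogen as such goes with the value of compound 4.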